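Replacing the Urea Phenyl with a Dimethylaminoethyl Chain

This account rests on a few compounds, and the source may have more. Where it says the series, first, only, none or still open, it means among the compounds named here.

Compound 1 `CN(c1ccc(NC(=O)Nc2ccccc2)cc1)c1ccnc(Nc2cccc(CS(C)(=O)=O)c2)n1` was tested in a functional assay on HUVEC cells (Homo sapiens) for inhibition (on this read-out lower numbers stand for stronger inhibition and higher numbers for weaker inhibition), where compound 1 gives 0.2 nM. Compound 2 `CCNC(=O)Nc1ccc(N(C)c2ccnc(Nc3cccc(CS(C)(=O)=O)c3)n2)cc1` carries ethyl in place of phenyl on an amide-type nitrogen, and in this assay compound 2 gives 3 nM. Of the two measured numbers, compound 1 has the lowest. Within the data shown here, the only measured step, a 15-fold higher number from compound 1 to compound 2 (1.18 log units; beyond the scatter), is large and runs toward weaker inhibition when phenyl leaves that nitrogen.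

Compound 3 `CN(C)CCNC(=O)Nc1ccc(N(C)c2ccnc(Nc3cccc(CS(C)(=O)=O)c3)n2)cc1` has not yet been measured. It differs from compound 1 by 2-(dimethylamino)ethyl in place of phenyl on an amide-type nitrogen. The measured step bears directly on this change, since in it phenyl also left the same amide-type nitrogen and a group with no ring entered. A step of similar size and direction is therefore expected in this assay.

For compound 3 the expected value is 3 nM, with a range from 0.8 nM to 12 nM. The expected step is a 15-fold higher number from compound 1 to compound 3 (1.18 log units; beyond the scatter).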

Compound 3, half-maximal inhibitory concentration: 530 nM
Estimate against measurement, compound 3: 180-fold (2.25 log units) below; the measured number lies above the stated range.
By their numbers in this assay, from the lowest: compound 1; then compound 2; then compound 3.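

This position tolerates changes less well than the ethyl compound suggested: what enters matters as well as the loss of phenyl. In this assay, 2-(dimethylamino)ethyl on the amide-type nitrogen gives a 2700-fold higher number from compound 1 to compound 3 (3.42 log units; beyond the scatter) and so lies well beyond the ethyl compound. Adding the dimethylamino group to the ethyl chain alone gives a 180-fold higher number from compound 2 to compound 3 (2.25 log units; beyond the scatter) and thus costs more than the earlier change from phenyl to ethyl, while no measurement here explains the loss of inhibition.

The compounds shown cannot tell whether the amine nitrogen itself or merely a larger chain end is responsible. A methoxyethyl chain, a hydroxyethyl chain or a longer chain ending in dimethylamino would help separate these possibilities.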